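This account rests on a few compounds, and the source may have more. Where it says the series, first, only, none or still open, it means among the compounds named here.

Of the compounds shown here, two built on a shared core have been measured in a functional assay on the whole organism for antagonist activity, with Mus musculus as the target, at a dose of 10 mg/kg by the oral route; on this read-out lower numbers stand for a weaker effect and higher numbers for a stronger effect at the one dose given. Compound 1, `C[C@]1(c2ccc(O)cc2)COc2cc(O)ccc2[C@H]1CCCCCCCCC[S+]([O-])CCCC(F)(F)C(F)(F)F`, gives 66% in this assay. Compound 2, `C[C@]1(c2ccc(O)cc2)CSc2cc(O)ccc2[C@H]1CCCCCCCCCC(CCCC(F)(F)C(F)(F)F)C(=O)O`, gives 81% in this assay, the highest of the two numbers, and its gap to compound 1 lies beyond the scatter. Among the compounds with values here, no step between measured compounds that differ in one place is available, so the two values show only that compound 2 sits above compound 1.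

Compound 3, `C[C@]1(c2ccc(O)cc2)CSc2cc(O)ccc2[C@H]1CCCCCCCCCC(CCCC(F)(F)C(F)(F)C(F)(F)C(F)(F)F)C(=O)O`, has not yet been measured. It differs from compound 2 in one place: 1,1,2,2,2-pentafluoroethyl in place of fluoro on a saturated chain carbon bound to two fluorine atoms and a saturated chain carbon. Within the data shown here, no measured pair speaks to a change of this kind, so the expectation rests on compound 2 alone. The expected change, a number 1 percentage points lower from compound 2 to compound 3 (within the scatter), is none beyond the scatter. Compound 3 is therefore estimated to give 80% in this assay, with a range from 65% to 92%.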

Compound 3, a percentage reported as inhibition, in the whole organism at one dose (the size of the read-out at that dose, not a potency): 86%
The estimate for compound 3 lay 6 percentage points below the measured number, and the stated range covers the measured number.
By their numbers in this assay, from the lowest: compound 1; then compounds 2 and 3 (each within the scatter of the next).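

In this assay, within the data shown here, the change gives the first step that can be read at this place: with 1,1,2,2,2-pentafluoroethyl in place of fluoro on a saturated chain carbon bound to two fluorine atoms and a saturated chain carbon, the result is a number 5 percentage points higher from compound 2 to compound 3 (within the scatter). A group of 7 heavy atoms can therefore enter for a single fluorine without carrying the read-out beyond the scatter at this one dose. Nothing available explains this outcome.

The two compounds leave open whether a nonafluorobutyl group at the same place would also stay within the scatter, and whether an amine in place of the carboxylic acid would keep the effect. A single dose also leaves open how compound 2 and compound 3 would compare at other doses.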